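A few compounds are considered here, and "the series" means these few. Any claim that something is new, unique, unknown or untested is made for them only; others in the source may bear on it.

For the measured compounds named here, compound 1 `CNC(=O)N1CCCc2ccc(NC(=O)c3ccc(-c4cc[nH]n4)cc3)cc21` is one of two compounds measured in a functional assay on MV4-11 cells (Homo sapiens) for antiproliferative activity, with a stated time of 6 days; a higher number here means a weaker inhibitor, a lower number a stronger inhibitor. In this assay compound 1 gives 550 nM, while compound 2 `CNC(=O)N1CCCc2ccc(NC(=O)c3cccc(-c4ccn(C)n4)c3)cc21` gives 980 nM, and the two numbers lie within the usual scatter of one another. Compound 3 `CNC(=O)N1CCCc2ccc(NC(=O)c3ccc(-c4ccn(C)n4)cc3)cc21` differs from compound 1 by methyl in place of hydrogen on an aromatic nitrogen. Going by the values given here, no measured pair shows this change alone, so only a modest step is expected from compound 1 to compound 3 in this assay, if any, toward a weaker inhibitor: a 1.6-fold higher number from compound 1 to compound 3 (0.21 log units; within the scatter). Because compound 2, which also carries the methylated ring, gives 980 nM, compound 3 is estimated at 900 nM, with a range from 300 nM to 3000 nM.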

Compound 3, half-maximal inhibitory concentration: 830 nM
For compound 3 the middle estimate is 1.1-fold (0.04 log units) above the measured one; measured number inside the range.
By their numbers in this assay, from the lowest: compounds 1, 3 and 2 (each within the scatter of the next).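

With methyl in place of hydrogen on the aromatic nitrogen, the pair gives a direct reading of this change in this assay: a 1.5-fold higher number from compound 1 to compound 3 (0.18 log units; within the scatter). The hydrogen on this nitrogen can therefore be replaced by methyl with the number staying in the same range, so the 1-methyl-1H-pyrazol-3-yl group is tolerated here. Nothing measured on these compounds offers an explanation for this result.

As far as these compounds go, what remains open is whether a larger group on this nitrogen, such as an ethyl group, a longer chain or a chain ending in an amine, would also keep the number in this range.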